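From Fluoro to Bromo: One Halogen Swap

This account rests on a few compounds, and the source may have more. Where it says the series, first, only, none or still open, it means among the compounds named here.

In a functional assay on B16-BL6 cells (Mus musculus) for cytotoxicity, read by MTT assay, with a stated time of 48 h (on this read-out lower numbers stand for stronger inhibition and higher numbers for weaker inhibition), compound 1 `CNC(=O)c1ccc(Sc2cccc(NC(=S)Nc3ccc(F)c(C(F)(F)F)c3)c2)nc1` gives 42400 nM. Compound 2 `CNC(=O)c1ccc(Sc2cccc(NC(=S)Nc3ccc(F)c(F)c3)c2)nc1` gives 58200 nM, and the two cannot be told apart, as a 1.4-fold higher number from compound 1 to compound 2 (0.14 log units; within the scatter) shows. Compound 3 `CNC(=O)c1ccc(Sc2cccc(NC(=S)Nc3ccc(F)c(Cl)c3)c2)nc1` gives > 100000 nM, which is a limit of the assay. Compound 4 `CNC(=O)c1ccc(Sc2cccc(NC(=S)Nc3ccc(Br)c(C(F)(F)F)c3)c2)nc1` differs from compound 1 by a single halogen: bromo in place of fluoro on an aromatic carbon. Within the data shown here, no measured step makes this exact swap. The closest is a halogen swap at a different place, an at least 1.7-fold higher number from compound 2 to compound 3 (0.23 log units; that floor lies within the scatter). Compound 1 also stands clear of compound 3, through an at least 2.3-fold higher number from compound 1 to compound 3 (0.37 log units; beyond the scatter), but that change replaces trifluoromethyl. No step beyond the scatter is therefore expected in this assay. The expected change is a 1.2-fold higher number from compound 1 to compound 4 (0.07 log units; within the scatter). Compound 4 is estimated at 50000 nM, with an expected range from 20000 nM to 100000 nM.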

Compound 4, half-maximal inhibitory concentration: > 100000 nM
Compound 4: a limit, no number; the forecaster's own chance of this, stated with the estimate: 30%; middle value at least 2.0-fold (0.30 log units) from the limit.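

Compounds 1, 2 and 3 all carry fluoro at this position, ortho to a trifluoromethyl group, so they could not show what a change here does. In this assay, replacing that fluoro with bromo gives a step beyond the scatter: an at least 2.3-fold higher number from compound 1 to compound 4 (0.37 log units; beyond the scatter). The value of compound 4 is a limit and not a number, so this step is only a floor: the limit of > 100000 nM in this assay, at which 2 of the 4 values shown sit.

From the compounds shown here alone, how large the true step is stays open. So does whether an amine or a methoxy group at this position would keep the read-out of compound 1.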